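Fluorophenyl isomer of compound 3: working estimate

The source may hold more compounds than are shown below. What is called first, only, known or untested is meant among the compounds shown, and "the series" means these compounds.

In a functional assay on HL-60 cells (Homo sapiens) for inhibition, read by MTT assay, with a stated time of 72 h (on this read-out higher numbers stand for weaker inhibition and lower numbers for stronger inhibition), compound 1 `Cc1nc(-c2ccc(F)cc2)c(C(=O)N2CCN(c3cccc(Cl)c3)CC2)o1` gives 40.1 nM and compound 3 `COc1cccc(N2CCN(C(=O)c3oc(C)nc3-c3ccc(F)cc3)CC2)c1` gives 112 nM, the higher of the two numbers available. Methoxy in place of chloro accounts for a 2.8-fold higher number from compound 1 to compound 3 (0.45 log units; beyond the scatter), a modest step. An isomer of compound 1, compound 2 `Cc1nc(-c2ccc(F)cc2)c(C(=O)N2CCN(c3ccc(Cl)cc3)CC2)o1`, is reported as "not active" (no number reported), without a number.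

Compound 4 `COc1cccc(N2CCN(C(=O)c3oc(C)nc3-c3cccc(F)c3)CC2)c1` is an isomer of compound 3: 3-fluorophenyl in place of 4-fluorophenyl on an aromatic carbon. The change is 3-fluorophenyl in place of 4-fluorophenyl on an aromatic carbon. Going by the values given here, no measured step touches this group, so the evidence is indirect. The methoxy step, a 2.8-fold higher number from compound 1 to compound 3 (0.45 log units; beyond the scatter), lies elsewhere in the molecule and offers only a guide to size. In the same way, compound 2 at "not active" (no number reported) shows that an isomer in this series can fail to give a number. A modestly higher number is therefore expected in this assay, with wide uncertainty. The expected change is a 1.8-fold higher number from compound 3 to compound 4 (0.25 log units; within the scatter). For compound 4 the estimated value is 200 nM, with an expected range of 50 nM to 800 nM.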

Compound 4, half-maximal inhibitory concentration: "not active" (no number reported)
No number was reported for compound 4, and the estimate cannot be compared.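

Going by these compounds alone, compound 4 carries no number, and no step from compound 3 to compound 4 can be read. No supporting data shown bear on this result. The compounds shown leave open how large a change 3-fluorophenyl in place of 4-fluorophenyl brings on this read-out.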